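From Acetoxy to Ethoxy on a Shared Core

A few compounds are considered here, and "the series" means these few. Any claim that something is new, unique, unknown or untested is made for them only; others in the source may bear on it.

Among the compounds with values here, in an ADME assay on Vero cells (Chlorocebus sabaeus) for cytotoxicity, read by neutral red uptake (on this read-out higher numbers stand for weaker inhibition and lower numbers for stronger inhibition), compound 1 (`COC(/C=C/c1ccc(O)cc1)=C1\C(=O)C=C(C)C1=O`) gives 3.7 ug/mL and compound 2 (`CC(=O)OC(/C=C/c1ccccc1)=C1\C(=O)C=C(C)C1=O`) gives 5.5 ug/mL as the only numbers so far. These two values lie within the usual scatter of each other, so the data do not separate compound 2 from compound 1. The two structures also differ in more than one place, which means that no single structural change can be read from this pair.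

The next compound, compound 3 (`CCOC(/C=C/c1ccccc1)=C1\C(=O)C=C(C)C1=O`), keeps the core of compound 2 and changes one group (ethyl in place of acetyl on an oxygen on an unsaturated carbon) by placing ethyl where acetyl stood on an oxygen on an unsaturated carbon, so that acetoxy becomes ethoxy. Within the data shown here, no measured pair shows this change directly. With compound 2 at 5.5 ug/mL as the only close reference, the expectation in this assay is for no change beyond the scatter. The estimated step is a 1.1-fold lower number from compound 2 to compound 3 (0.04 log units; within the scatter) in size and is expected to stay within that scatter. The estimated value for compound 3 is 5 ug/mL with an expected range from 2 ug/mL to 12 ug/mL when it is measured.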

Compound 3, half-maximal inhibitory concentration: 4.8 ug/mL
The estimate for compound 3 lay 1.0-fold (0.02 log units) above the measured number; low and high end bracket the measured number.
By their numbers in this assay, from the lowest: compounds 1, 3 and 2 (each within the scatter of the next).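

In this assay, within the data shown here, compound 2 and compound 3 form the first pair that differs in one place, and so the first pair with a step that can be read (a 1.1-fold lower number from compound 2 to compound 3 (0.06 log units; within the scatter)). On an oxygen on an unsaturated carbon, then, ethyl in place of acetyl stays within the scatter: acetoxy and ethoxy are not separated here, even though the change removes the acetyl carbonyl from the shared core. Nothing in the information available explains this outcome.

The compounds shown leave open whether a longer chain on that oxygen, or a chain carrying an amine or a carboxylic acid, would also stay within the scatter, and they show this change on one core and in one assay only. Going by these compounds, compound 1 differs from compound 2 and from compound 3 in more than one place, so steps to it cannot be read, and what each of its differences contributes on its own remains open.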